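A Second Methyl on the Anilide Ring of Compound 1

A few compounds are considered here, and "the series" means these few. Any claim that something is new, unique, unknown or untested is made for them only; others in the source may bear on it.

Three anilides sharing one core were tested in an in vitro assay on BTI-TN-5B1-4 cells for inhibition of Amine oxidase [flavin-containing] A (Homo sapiens), read by fluorescence; on this read-out higher numbers stand for weaker inhibition and lower numbers for stronger inhibition. Compound 1 `Cc1ccc(NC(=O)c2cc3ccccc3oc2=O)cc1` gives 19500 nM in this assay. Compound 2 `CCc1ccc(NC(=O)c2cc3ccccc3oc2=O)cc1` gives 15700 nM, and compound 3 `O=C(Nc1ccc(F)cc1)c1cc2ccccc2oc1=O` gives 13100 nM. The three numbers differ from one another only within the usual scatter, so compound 1 cannot be called weaker or stronger than its two partners; it simply sits among them.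

The unmeasured compound 4 `Cc1ccc(NC(=O)c2cc3ccccc3oc2=O)c(C)c1` differs from compound 1 by methyl in place of hydrogen on an aromatic carbon. The two measured steps that start from compound 1 both changed the substituent on the same aromatic ring: a 1.2-fold lower number from compound 1 to compound 2 (0.09 log units; within the scatter) and a 1.5-fold lower number from compound 1 to compound 3 (0.17 log units; within the scatter). Neither moved the number beyond the scatter, so small changes on this ring have so far left this assay indifferent. The added methyl in compound 4 is another small change on that ring, and no step beyond the scatter is expected; the estimated step is a 1.1-fold lower number from compound 1 to compound 4 (0.06 log units; within the scatter). For compound 4 the expected value in this assay is 17000 nM, with a likely range from 8000 nM to 40000 nM.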

Compound 4, half-maximal inhibitory concentration: 12300 nM
Compound 4: middle estimate off by 1.4-fold (0.14 log units), on the high side; the range from low to high includes it.
By their numbers in this assay, from the lowest: compounds 4, 3, 2 and 1 (each within the scatter of the next).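

Until now, every change had swapped the group already on the anilide ring, leaving the other ring positions untouched. Within the data shown here, compound 4 is the first to fill a new place, ortho to a large group and meta to a methyl group. In this assay, adding a methyl there gives a 1.6-fold lower number from compound 1 to compound 4 (0.20 log units; within the scatter), so this place, like the earlier one, shows no change beyond the scatter for a single small group. Nothing measured here explains this result.

The compounds shown leave open whether a larger group at this place, such as a longer chain, an amine or a carboxylic acid, would produce a step beyond the scatter. They also leave open whether this added methyl would give a similar step alongside the fluoro of compound 3.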